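A few compounds are considered here, and "the series" means these few. Any claim that something is new, unique, unknown or untested is made for them only; others in the source may bear on it.

Series notes. The shared core is that of compound 1 `COc1cc(-c2nc3cc(/C=C4\SC(=O)NC4=O)ccc3[nH]2)cc(OC)c1OC`; in a functional assay on PC-3 cells (Homo sapiens) for inhibition, read by MTT assay, with a stated time of 48 h (on this read-out lower numbers stand for stronger inhibition and higher numbers for weaker inhibition), compound 1 gives 12000 nM. Compound 2 `COc1cc(-c2nc3cc(/C=C4\SC(=O)N(CC(=O)N5CCCCC5)C4=O)ccc3[nH]2)cc(OC)c1OC` carries ((piperidin-1-yl)carbonyl)methyl on the amide-type nitrogen in the ring, and in this assay compound 2 gives 14700 nM; the step of a 1.2-fold higher number from compound 1 to compound 2 (0.09 log units; within the scatter). Compound 2 thus holds the highest of the two numbers available, with compound 1 the nearest. Compound 3 `COc1cc(OC)c(-c2nc3cc(/C=C4\SC(=O)N(CC(=O)N5CCCCC5)C4=O)ccc3[nH]2)cc1OC` in this assay reaches only a limit of the assay, > 50000 nM. The step of an at least 3.4-fold higher number from compound 2 to compound 3 (0.53 log units; beyond the scatter), its end point sitting at the limit of > 50000 nM in this assay, at which 1 of the 3 values shown sits.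

Compound 4 `COc1cc(CN2C(=O)S/C(=C\c3ccc4[nH]c(-c5cc(OC)c(OC)c(OC)c5)nc4c3)C2=O)cc(OC)c1OC` is not yet measured. Compared with compound 2 it has 3,4,5-trimethoxyphenyl in place of (piperidin-1-yl)carbonyl on a saturated chain carbon bound to an amide-type nitrogen in a ring. Among the measured compounds shown here, the one measured step that bears on changing the group on that nitrogen is a 1.2-fold higher number from compound 1 to compound 2 (0.09 log units; within the scatter), which stayed within the scatter; the step of an at least 3.4-fold higher number from compound 2 to compound 3 (0.53 log units; beyond the scatter) concerns a different position and does not bear directly on this change. No shift beyond the scatter is therefore expected for compound 4 in this assay, and the expected step is a 1.0-fold higher number from compound 2 to compound 4 (0.01 log units; within the scatter). The estimate for compound 4 in this assay is 15000 nM, with a range from 5000 nM to 45000 nM.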

Compound 4, half-maximal inhibitory concentration: 10200 nM
Compound 4: the middle estimate sits 1.5-fold (0.17 log units) above what was measured; the measured number falls inside the stated range.
By their numbers in this assay, from the lowest: compounds 4, 1 and 2 (each within the scatter of the next). At a limit, above all of these: compound 3.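

In this assay, 3,4,5-trimethoxyphenyl in place of (piperidin-1-yl)carbonyl on a saturated chain carbon bound to an amide-type nitrogen in a ring gives a 1.4-fold lower number from compound 2 to compound 4 (0.16 log units; within the scatter). Until now this nitrogen offered a single comparison, hydrogen against ((piperidin-1-yl)carbonyl)methyl; a second group, with an aromatic ring of carbon only in place of a non-aromatic ring with one hetero atom, now also leaves the number within the scatter, so two different groups on that chain carbon read alike among compounds 2 and 4. Nothing measured here bears on why the number holds across this exchange.

From the compounds shown here alone, what remains open is whether this flat picture at the nitrogen extends to other kinds of group on the chain carbon, such as a carboxylic acid, an open-chain amine or a longer chain ending in the same 3,4,5-trimethoxyphenyl. Also open, going by these compounds, is how a compound carrying 3,4,5-trimethoxyphenyl on the chain would read in this assay with 2,4,5-trimethoxyphenyl in place of 3,4,5-trimethoxyphenyl on the aromatic carbon that changed in compound 3.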